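Swapping the Aryl Group: Compound 3 to Compound 4

The source may report more compounds than this note shows. Statements on the series, on what has been measured and on what is new or still open speak of the compounds shown alone.

In a functional assay on DU-145 cells (Homo sapiens) for antiproliferative activity, read by MTT assay, with a stated time of 48 h (a higher number here means a weaker inhibitor, a lower number a stronger inhibitor), compound 3 `C/C(=C\CC/C(C)=C/CC[C@@H]1[C@@]2(C)CCC(=O)C(C)(C)[C@H]2CC[C@@]1(C)O)CC/C=C(\C)C(=O)OCc1cn(-c2cccc(C)c2)nn1` gives 137000 nM. Compound 2 `C/C(=C\CC/C(C)=C/CC[C@@H]1[C@@]2(C)CCC(=O)C(C)(C)[C@H]2CC[C@@]1(C)O)CC/C=C(\C)C(=O)OCc1cn(C[C@@H]2O[C@H](n3ccc(=O)[nH]c3=O)C[C@H]2O)nn1` gives 33100 nM, so compound 3 holds the higher of these two numbers. In this assay, compound 1 `C/C(=C\CC/C(C)=C/CC[C@@H]1[C@@]2(C)CCC(=O)C(C)(C)[C@H]2CC[C@@]1(C)O)CC/C=C(\C)C(=O)OCc1cn(-c2ccc([N+](=O)[O-])cc2)nn1` gives only a limit, > 150000 nM.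

Compound 4 `C/C(=C\CC/C(C)=C/CC[C@@H]1[C@@]2(C)CCC(=O)C(C)(C)[C@H]2CC[C@@]1(C)O)CC/C=C(\C)C(=O)OCc1cn(-c2ccccc2Cl)nn1` differs from compound 3 by 2-chlorophenyl in place of 3-methylphenyl on an aromatic nitrogen, with 2-chlorophenyl in place of 3-methylphenyl on an aromatic nitrogen. Within the data shown here, the only measured exchange of one aryl group for another at that nitrogen is an at least 1.0-fold lower number from compound 1 to compound 3 (0.03 log units; that floor lies within the scatter). No step beyond the scatter is therefore expected in this assay, and the expected step is a 1.1-fold lower number from compound 3 to compound 4 (0.06 log units; within the scatter). Compound 4 is estimated at 120000 nM, with an expected range of 60000 nM to 150000 nM.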

Compound 4, half-maximal inhibitory concentration: > 150000 nM
Compound 4 was reported as a limit; the forecaster's own chance of this, stated with the estimate: 35%; middle value at least 1.2-fold (0.09 log units) away from the limit.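

The exchange of 3-methylphenyl for 2-chlorophenyl on this aromatic nitrogen in this assay gives an at least 1.0-fold higher number from compound 3 to compound 4 (0.03 log units; that floor lies within the scatter). A third aryl group at this position therefore brings no readable gain, and a chlorine-bearing ring joins the nitro-bearing ring of compound 1 at the top of the measurable range: the limit of > 150000 nM in this assay, at which 2 of the 4 values shown sit. Compound 1 and compound 4 are both limits, so the step between them cannot be read.

Still open, as far as these compounds go, is whether a phenyl ring carrying an amine or a carboxylic acid would give a number under that limit. Also open, from the compounds shown here alone, is how a longer chain between the aromatic nitrogen and the phenyl ring would read.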